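A larger group on the sulfonyl sulfur of compound 3

A few compounds are considered here, and "the series" means these few. Any claim that something is new, unique, unknown or untested is made for them only; others in the source may bear on it.

Compound 1 `CC(C)S(=O)(=O)c1c(Cl)ccc(NC(=O)Nc2cccc(F)c2Cl)c1O`: 198 ng.h/mL
Compound 2 `CN1CC[C@H](S(=O)(=O)c2c(Cl)ccc(NC(=O)Nc3cccc(F)c3Cl)c2O)C1`: 432 ng.h/mL
Compound 3 `CN1CC2(CC(S(=O)(=O)c3c(Cl)ccc(NC(=O)Nc4cccc(F)c4Cl)c3O)C2)C1`: 1050 ng.h/mL

These values come from an ADME assay on the whole organism (blood, Mus musculus, strain C57BL/6) for pharmacokinetics, read by HPLC, with a stated time of 4 h, at a dose of 2 mg/kg by the intraperitoneal route; a lower number here means less compound in the circulation, a higher number more compound in the circulation at the dose given. Compound 3 stands highest of the three at 1050 ng.h/mL, clear of both others. The next structure, compound 4 `CN1CCC2(CC1)CC(S(=O)(=O)c1c(Cl)ccc(NC(=O)Nc3cccc(F)c3Cl)c1O)C2`, keeps the shared core and changes only what sits on the sulfonyl sulfur: a group of 10 heavy atoms (9 carbon, 1 nitrogen; one four-membered non-aromatic ring of carbon only, one six-membered non-aromatic ring with 1 hetero atom) in place of a group of 8 heavy atoms (7 carbon, 1 nitrogen; one four-membered non-aromatic ring of carbon only, one four-membered non-aromatic ring with 1 hetero atom), on a sulfonyl sulfur.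

Three measured changes at this same place bear on it. They are a 2.2-fold higher number from compound 1 to compound 2 (0.34 log units; beyond the scatter), a 2.4-fold higher number from compound 2 to compound 3 (0.39 log units; beyond the scatter), and, taken together, a 5.3-fold higher number from compound 1 to compound 3 (0.72 log units; beyond the scatter). All are modest, and among these three compounds a group with more heavy atoms always came with a higher number; none goes against this, though three compounds are a thin base. Among the compounds with values here, compound 4 also carries a six-membered non-aromatic ring with 1 hetero atom where compound 3 has a four-membered one, and no measured pair shows that exchange. So only a small further rise is expected, perhaps none beyond the scatter. The expected change in this assay is a 1.2-fold higher number from compound 3 to compound 4 (0.09 log units; within the scatter). For compound 4 the estimated value is 1300 ng.h/mL, with an expected range of 550 ng.h/mL to 3000 ng.h/mL.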

Compound 4, area under the concentration-time curve: 1390 ng.h/mL
For compound 4 the middle estimate is 1.1-fold (0.03 log units) below the measured one; measured number inside the range.
By their numbers in this assay, from the lowest: compound 1; then compound 2; then compounds 3 and 4 (each within the scatter of the next).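

In this assay, the exchange of a four-membered non-aromatic ring with 1 hetero atom for a six-membered one gives a 1.3-fold higher number from compound 3 to compound 4 (0.12 log units; within the scatter), which lies within the scatter, so this exchange shows no readable effect at the sulfonyl sulfur. The new group still stands clear of the smaller ones, with a 3.2-fold higher number from compound 2 to compound 4 (0.51 log units; beyond the scatter) and a 7.0-fold higher number from compound 1 to compound 4 (0.85 log units; beyond the scatter), so the link between more heavy atoms and a higher number holds against those two groups but cannot be read between the two largest. Nothing measured here explains any of these steps.

The compounds shown leave open whether the nitrogen matters at all, since the isopropyl group of compound 1 differs from the other groups in both its lack of nitrogen and its lack of a ring. Within the data shown here, a cyclohexyl group on the sulfonyl sulfur would separate those two features, while a larger group than the one in compound 4 would test whether the number can climb any further at this place.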